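This account rests on a few compounds, and the source may have more. Where it says the series, first, only, none or still open, it means among the compounds named here.

In a functional assay on K562 cells (Homo sapiens), read by MTT assay, with a stated time of 72 h (on this read-out lower numbers stand for stronger inhibition and higher numbers for weaker inhibition), compound 1 `CNc1ncnc2c1c(-c1ccccc1)cn2[C@@H]1O[C@H](CO)[C@@H](O)[C@H]1O` gives only a limit, > 20000 nM. Compound 2 `CNc1ncnc2c1c(-c1cccs1)cn2[C@@H]1O[C@H](CO)[C@@H](O)[C@H]1O` likewise gives only a limit, > 20000 nM. Compound 3 `CNc1ncnc2c1c(-c1ccoc1)cn2[C@@H]1O[C@H](CO)[C@@H](O)[C@H]1O` also gives only a limit, > 20000 nM. Compound 2 therefore stands where every value in the set stands, at the limit of > 20000 nM in this assay, at which 3 of the 3 values shown sit. For the measured compounds named here, the steps a step that the two limits leave unreadable from compound 1 to compound 2, a step that the two limits leave unreadable from compound 1 to compound 3 and a step that the two limits leave unreadable from compound 2 to compound 3 cannot be sized, so the series so far says nothing about how any change moves this assay. Compound 4 `CN(C)c1ncnc2c1c(-c1cccs1)cn2[C@@H]1O[C@H](CO)[C@@H](O)[C@H]1O` differs from compound 2 by methyl in place of hydrogen on a nitrogen on an aromatic ring. Going by the values given here, no measured step touches that nitrogen, and none of the measured steps is readable. With nothing to build on, the step that the limit leaves unreadable from compound 2 to compound 4 is expected to be none beyond the scatter. Compound 4 is expected to return 30000 nM, within 10000 nM to 100000 nM, most likely again as a limit only.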

Compound 4, half-maximal inhibitory concentration: > 20000 nM
Compound 4: only a limit was reported (the forecaster's own chance of this, stated with the estimate: 85%); the middle value is on the limit's open side.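

No size can be read for the change from compound 2 to compound 4. In this assay compound 4 gives only a limit, > 20000 nM. The compounds shown leave open whether any change to the shared core moves this assay at all: the limit of > 20000 nM in this assay, at which 4 of the 4 values shown sit.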